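The source may hold more compounds than are shown below. What is called first, only, known or untested is meant among the compounds shown, and "the series" means these compounds.

Measured so far in a functional assay on HL-60 cells (Homo sapiens) for cytotoxicity, read by luminescence and CellTiter-Glo, with a stated time of 3 days; a higher number here means a weaker inhibitor, a lower number a stronger inhibitor:

compound 1 `N#Cc1ccc(NC(=O)c2ccccc2O)cc1` gives 4620 nM here
compound 2 `N#Cc1ccc(NC(=O)c2ccc(Br)cc2O)cc1` gives 1210 nM here

Compound 2 holds the lower of the two numbers, and compound 1 stands above it. For the measured compounds named here, the single measured step of a 3.8-fold lower number from compound 1 to compound 2 (0.58 log units; beyond the scatter) comes from bromo in place of hydrogen on an aromatic carbon and lies beyond the scatter.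

Compound 3 `N#Cc1ccc(NC(=O)c2ccc(-c3ccncc3)cc2O)cc1` is not yet measured. It carries pyridin-4-yl in place of bromo on an aromatic carbon, the same carbon that gained the bromo in compound 2. The change pyridin-4-yl in place of bromo on an aromatic carbon leaves the rest of the structure as it is. Going by the values given here, the step of a 3.8-fold lower number from compound 1 to compound 2 (0.58 log units; beyond the scatter) is the only guide at this carbon, and it was modest, with no measured case of a ring entering there. A modest move is therefore expected in this assay at the most, leaning toward a lower number, and it may stay within the scatter. The expected step of a 1.3-fold lower number from compound 2 to compound 3 (0.13 log units; within the scatter) is small and uncertain. For compound 3 the estimated value is 900 nM within a range from 250 nM to 3500 nM on present data.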

Compound 3, half-maximal inhibitory concentration: 7090 nM
Estimate against measurement, compound 3: 7.9-fold (0.90 log units) below, and the stated range ends below it.
By their numbers in this assay, from the lowest: compound 2; then compounds 1 and 3 (each within the scatter of the next).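

In this assay, the carbon meta to the hydroxy group and para to the large group proves selective about what it carries: pyridin-4-yl in place of bromo gives a 5.9-fold higher number from compound 2 to compound 3 (0.77 log units; beyond the scatter) and removes the advantage that bromo had held over hydrogen. Set against hydrogen at the same carbon, pyridin-4-yl gives a 1.5-fold higher number from compound 1 to compound 3 (0.19 log units; within the scatter), so this ring does not separate from the unsubstituted compound 1, and the size of the entering group alone does not predict a lower number across these three compounds, since only bromo stands apart from hydrogen here. Nothing available on these compounds bears on why bromo and pyridin-4-yl behave differently at this carbon.

The compounds shown leave open whether the ring nitrogen matters or the ring as a whole, which a phenyl or pyridin-3-yl group at the same carbon would begin to separate. They also leave open whether bromo is a special case or one of a wider set of small groups, as chloro, methyl or methoxy at this carbon would show, while the nitrile and the hydroxy group stay unchanged throughout and are therefore untested.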